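Working notes: fluoro for methoxy on the carbamate aryl

The compounds below may be only part of what the source reports. "The series", "measured", "known", "first", "only" and "open" are said of these compounds alone.

Measured so far:
- compound 1, `CCOc1cc(=O)n(CCCO)c2c1CC(C/C=C(\C)CCC=C(C)C)C(C)(C)C2`, gives 67.8% in a functional assay on PANC-1 cells (Homo sapiens) for inhibition, read by MTT assay, with a stated time of 24 h, tested at 10 uM; on this read-out higher numbers stand for more inhibition at the one concentration tested (going by the name of the read-out) and lower numbers for less inhibition
- compound 2, `COc1ccc(NC(=O)Oc2cc(=O)n(CCCO)c3c2CC(C/C=C(\C)CCC=C(C)C)C(C)(C)C3)cc1`, gives 64.1% in this assay

Compound 2 stands lowest of the two numbers, but the nearest and only other value, that of compound 1, sits within the scatter: a number 3.7 percentage points lower from compound 1 to compound 2 (within the scatter). The two compounds therefore cannot be ordered on this read-out.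

Compound 3, `CC(C)=CCC/C(C)=C/CC1Cc2c(OC(=O)Nc3ccc(F)cc3)cc(=O)n(CCCO)c2CC1(C)C`, has not yet been measured. It differs from compound 2 by fluoro in place of methoxy on an aromatic carbon.

Going by the values given here, only one measured step exists, and it concerns another position of the core, exchanging ethyl for the whole (4-methoxyphenyl)carbamoyl group on the ring oxygen; it was a number 3.7 percentage points lower from compound 1 to compound 2 (within the scatter). Among the compounds with values here, no step touches the methoxy itself, so nothing here tells how much the aromatic ring of the carbamate contributes. Given that even the large change from compound 1 to compound 2 stayed within the scatter, a small change at the far end of that group is expected to produce no step beyond the scatter in this assay either.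

Compound 3 is therefore estimated at 63% in this assay, between 50% and 76%, meaning an expected step of a number 1.1 percentage points lower from compound 2 to compound 3 (within the scatter).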

Compound 3, a percentage reported as inhibition, at one concentration (the size of the read-out at that concentration, not a potency): 43.9%
Compound 3: middle estimate off by 19.1 percentage points, on the high side, outside the stated range (below it).
By their numbers in this assay, from the lowest: compound 3; then compounds 2 and 1 (each within the scatter of the next).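

The substituent on this aromatic carbon of the carbamate aryl matters in this assay: with fluoro in place of methoxy there is a number 20.2 percentage points lower from compound 2 to compound 3 (beyond the scatter), whereas the much larger exchange of ethyl for (4-methoxyphenyl)carbamoyl on the ring oxygen stayed within the scatter (a number 3.7 percentage points lower from compound 1 to compound 2 (within the scatter)). The carbamate alone therefore does not set the level across these three compounds, since the (4-fluorophenyl)carbamoyl group, unlike its 4-methoxyphenyl counterpart, separates from ethyl, with a number 23.9 percentage points lower from compound 1 to compound 3 (beyond the scatter). No measurement at hand accounts for the difference between methoxy and fluoro on this ring.

From the compounds shown here alone, it remains open whether the lower number belongs to the arrival of fluoro or to the departure of methoxy, a question that hydrogen, chloro or an amine on the same aromatic carbon would help to settle. Also open, going by these compounds, is whether the same methoxy to fluoro exchange would give a comparable step with a longer chain or a carboxylic acid in place of the hydroxypropyl chain on the ring nitrogen of the shared core.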